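Series notes: changing the aryl substituent of compound 1

The compounds below may be only part of what the source reports. "The series", "measured", "known", "first", "only" and "open" are said of these compounds alone.

Measured so far in a functional assay on WM 266-4 cells (Homo sapiens) for antiproliferative activity, read by MTT assay, with a stated time of 24 h; a higher number here means a weaker inhibitor of growth, a lower number a stronger inhibitor of growth:
compound 1 `Fc1ccc(C2CC(c3ccc4c(c3)OCCO4)=NN2c2ccccc2)cc1` — 6050 nM
compound 2 `O=C(c1ccc2c(c1)OCCO2)N1N=C(c2ccc(Br)cc2)CC1c1ccccc1F` — 750 nM
compound 3 `Brc1ccc(C2CC(c3ccc4c(c3)OCCO4)=NN2c2ccccc2)cc1` — 3010 nM

Compound 1 has the highest number of the three in this assay. Its nearest neighbour is compound 3: the step of a 2.0-fold lower number from compound 1 to compound 3 (0.30 log units; within the scatter) is within the scatter, so the two cannot be ordered. Among the measured compounds shown here, compound 2 stands furthest from compound 1, beyond the scatter, but it differs from compound 1 in more than one place, so the two values show only that the pair is not alike.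

Compound 4 `FC(F)(F)c1ccc(C2CC(c3ccc4c(c3)OCCO4)=NN2c2ccccc2)cc1` differs from compound 1 by trifluoromethyl in place of fluoro on an aromatic carbon. For the measured compounds named here, the only measured step that bears on this change is the one from compound 1 to compound 3, in which a different group entered at the same aromatic carbon and the number moved within the scatter. A step of similar size is therefore expected here in this assay, at most a modest lowering of the number, and the expected step of a 1.5-fold lower number from compound 1 to compound 4 (0.18 log units; within the scatter) is taken as within the scatter. For compound 4 the estimate in this assay is 4000 nM, with a range from 1500 nM to 11000 nM.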

Compound 4, concentration for 50% growth inhibition: > 100000 nM
Compound 4: only a limit was reported; the forecaster's own chance of this, stated with the estimate: 5%; at least 25-fold (1.39 log units) between middle value and limit.
By their numbers in this assay, from the lowest: compound 2; then compounds 3 and 1 (each within the scatter of the next). At a limit, above all of these: compound 4.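

In this assay compound 4 is reported only as a limit, not as a number: the limit of > 100000 nM in this assay, at which 1 of the 4 values shown sits.

The aromatic carbon para to a large group therefore does not treat all replacements alike. Trifluoromethyl gives an at least 16-fold higher number from compound 1 to compound 4 (1.21 log units; beyond the scatter) and, measured against bromo, an at least 33-fold higher number from compound 3 to compound 4 (1.52 log units; beyond the scatter), while the step between the two halogens, a 2.0-fold lower number from compound 1 to compound 3 (0.30 log units; within the scatter), could not be ordered. The earlier pair alone gave no sign that this position could respond so strongly to the group it carries.

The compounds shown leave open how a methyl, a methoxy group or a nitrile at this carbon would compare, and so which feature of trifluoromethyl goes with the large step. Also open, going by these compounds, is whether trifluoromethyl in place of bromo in compound 2 would produce a step of similar size.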